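This account rests on a few compounds, and the source may have more. Where it says the series, first, only, none or still open, it means among the compounds named here.

In an ADME assay on microsomes from liver (Homo sapiens) for metabolic stability (a lower number here means that the compound disappears faster, a higher number that the compound lasts longer), compound 1 `Cc1nc(C(c2ccc(-c3ccc4cccc(F)c4c3)[nH]c2=O)C(C)C)[nH]c1C` gives 0.268 h. Compound 2 `CC(C)C(Cc1noc(=O)[nH]1)c1ccc(-c2ccc3cccc(F)c3c2)[nH]c1=O` gives > 3 h, which is a limit of the assay and not a number. Compound 3 `CC(C)C(c1noc(=O)[nH]1)c1ccc(-c2ccc3cccc(F)c3c2)[nH]c1=O`, not yet measured, differs from compound 2 by a group of 6 heavy atoms (2 carbon, 2 nitrogen, 2 oxygen; one five-membered aromatic ring with 3 hetero atoms) in place of a group of 7 heavy atoms (3 carbon, 2 nitrogen, 2 oxygen; one five-membered aromatic ring with 3 hetero atoms), on a saturated chain carbon bound to an aromatic carbon and a saturated chain carbon, on a saturated chain carbon bound to an aromatic carbon and a saturated chain carbon. Going by the values given here, the only measured step, an at least 11-fold higher number from compound 1 to compound 2 (1.04 log units; beyond the scatter), exchanged one ring group for a different kind, whereas compound 3 keeps one five-membered aromatic ring with 3 hetero atoms, so that large step bears only loosely here. In this assay, no change beyond the scatter is therefore expected, in either direction: a number no higher from compound 2 to compound 3 (the limit leaves the size open). For compound 3 the estimated half-life is 3 h, with an expected range from 1 h to 6 h.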

Compound 3, half-life: > 3 h
Compound 3: no number, only a limit (the forecaster's own chance of this, stated with the estimate: 50%); the middle value sits exactly at the limit.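

At this place, on a saturated chain carbon bound to an aromatic carbon and a saturated chain carbon, the group of 6 heavy atoms gives an at least 11-fold higher number from compound 1 to compound 3 (1.04 log units; beyond the scatter). The high reading in this assay therefore holds for the five-membered aromatic ring with 3 hetero atoms in both the 7-atom and the 6-atom group. The step between compound 2 and compound 3 cannot be read, because both readings are limits and not numbers: the limit of > 3 h in this assay, at which 2 of the 3 values shown sit.

Which of these two groups lasts longer stays open. So does how an amine or a carboxylic acid at this place would behave in this assay.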